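A few compounds are considered here, and "the series" means these few. Any claim that something is new, unique, unknown or untested is made for them only; others in the source may bear on it.

Compound 1 `FC(F)(F)c1ccc(C2CC(c3ccc4c(c3)OCCO4)=NN2c2ccccc2)cc1`: > 100000 nM (a limit)
Compound 2 `Ic1ccc(C2CC(c3ccc4c(c3)OCCO4)=NN2c2ccccc2)cc1`: 3470 nM

Among the compounds with values here, in a functional assay on WM 266-4 cells (Homo sapiens) for antiproliferative activity, read by MTT assay, with a stated time of 24 h (on this read-out lower numbers stand for stronger inhibition of growth and higher numbers for weaker inhibition of growth), compound 2 gives 3470 nM, the only actual number so far. The entry for compound 1 is a limit.

Compound 3 `Fc1ccccc1C1CC(c2ccc3c(c2)OCCO3)=NN1c1ccccc1` carries 2-fluorophenyl in place of 4-iodophenyl on a saturated ring carbon. Within the data shown here, the only measured guide is an at least 28-fold lower number from compound 1 to compound 2 (1.45 log units; beyond the scatter), a large step that rests on (the limit of > 100000 nM in this assay, at which 1 of the 2 values shown sits). It shows that a change on this aryl group can shift the read-out strongly, so a moderate rise in this assay is expected. The expected change is a 3.5-fold higher number from compound 2 to compound 3 (0.54 log units; beyond the scatter). For compound 3 the estimate is 12000 nM, with an expected range of 2500 nM to 60000 nM.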

Compound 3, concentration for 50% growth inhibition: 9120 nM
Compound 3: the middle estimate sits 1.3-fold (0.12 log units) above what was measured; the range from low to high includes it.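

In this assay, a halogen on this aryl group is not tied to 4-iodophenyl, since 2-fluorophenyl costs only a modest step: a 2.6-fold higher number from compound 2 to compound 3 (0.42 log units; beyond the scatter). The same group still compares well with 4-(trifluoromethyl)phenyl, with an at least 10-fold lower number from compound 1 to compound 3 (1.04 log units; beyond the scatter). That step is open-ended, as it rests on a limit and not on a number: the limit of > 100000 nM in this assay, at which 1 of the 3 values shown sits.

Compound 3 changes both the halogen and its place on the ring, so the two changes cannot be separated. On these data alone, whether 4-fluorophenyl, or an amine or a carboxylic acid on this aryl group, would hold the read-out remains open.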